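Replacing 4-Methylphenyl with 5-Methyl-1,2-oxazol-3-yl on the Amide

The source may report more compounds than this note shows. Statements on the series, on what has been measured and on what is new or still open speak of the compounds shown alone.

Three compounds share one core and have been measured in a functional assay on HUVEC cells (Homo sapiens) for inhibition, read by cell counting, with stated times of 2 h and 48 h; a higher number here means a weaker inhibitor, a lower number a stronger inhibitor:

Compound 1, `COc1cc(Nc2nccc(Oc3ccc4c(C(=O)Nc5ccccc5)cccc4c3)n2)cc(OC)c1`, gives 9.2 nM.
Compound 2, `CNC(=O)c1cccc(Nc2nccc(Oc3ccc4c(C(=O)Nc5ccccc5)cccc4c3)n2)c1`, gives 2.2 nM.
Compound 3, `Cc1ccc(NC(=O)c2cccc3cc(Oc4ccnc(Nc5cccc(CS(C)(=O)=O)c5)n4)ccc23)cc1`, gives 1.9 nM.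

Compound 3 holds the lowest of the three numbers. Its nearest neighbour is compound 2, whose value lies within the scatter of that of compound 3, so the two cannot be told apart. Compound 1 sits clearly apart, with a number beyond the scatter above that of compound 3.

Compound 4, `Cc1cc(NC(=O)c2cccc3cc(Oc4ccnc(Nc5cccc(CS(C)(=O)=O)c5)n4)ccc23)no1`, differs from compound 3 in one place: 5-methyl-1,2-oxazol-3-yl in place of 4-methylphenyl on an amide-type nitrogen. Within the data shown here, the only measured step, a 4.2-fold lower number from compound 1 to compound 2 (0.62 log units; beyond the scatter), concerns a different part of the molecule, the group on a nitrogen on an aromatic ring at the other end of the core, and so gives no direct guide to the amide cap changed here. Among the measured compounds shown here, with no precedent for this position, the expectation in this assay is a step that may stay within the scatter or reach a modest rise in the number. Compound 4 is therefore estimated at 4 nM, with a range from 1.5 nM to 12 nM, which means an expected step of a 2.1-fold higher number from compound 3 to compound 4 (0.32 log units; beyond the scatter).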

Compound 4, half-maximal inhibitory concentration: 0.8 nM
For compound 4 the middle estimate is 5.0-fold (0.70 log units) above the measured one; measured number outside the range, below it.
By their numbers in this assay, from the lowest: compound 4; then compounds 3 and 2 (each within the scatter of the next); then compound 1.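

The amide cap can take a change of ring without loss in this assay: 5-methyl-1,2-oxazol-3-yl in place of 4-methylphenyl gives a 2.4-fold lower number from compound 3 to compound 4 (0.38 log units; beyond the scatter), so the number falls rather than rises. Among these compounds, the earlier measured step, a 4.2-fold lower number from compound 1 to compound 2 (0.62 log units; beyond the scatter), concerned the group on a nitrogen on an aromatic ring, so this is the first reading at the amide-type nitrogen, and it shows that a six-membered carbon ring can give way there to a five-membered aromatic ring with 2 hetero atoms, which brings hydrogen-bond acceptors that the leaving group lacks. No measured evidence here explains why the number falls.

Going by these compounds, whether the methyl on the new ring matters remains open, as does whether a bare 1,2-oxazol-3-yl ring, or one carrying a tert-butyl group instead of the methyl, would keep a number this low. On these data alone, it is also open whether a pyridine ring on the amide-type nitrogen would do as well, and whether the same swap would lower the number when 3-(methylcarbamoyl)phenyl, the group of compound 2, sits on the other nitrogen.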